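The source may report more compounds than this note shows. Statements on the series, on what has been measured and on what is new or still open speak of the compounds shown alone.

- Compound 1 `O=C1/C(=C\c2ccc(O)cc2)c2ccccc2N1c1c(Cl)cccc1Cl` gives 20 ug/mL
- Compound 2 `Cc1ccc2nc(Cl)c(/C=C3\C(=O)N(c4c(Cl)cccc4Cl)c4ccccc43)cc2c1` gives > 100 ug/mL as a limit

Among the measured compounds shown here, in a functional assay on MCF7 cells (Homo sapiens) for cytotoxicity, read by MTT assay, with a stated time of 72 h (on this read-out lower numbers stand for an effect already at smaller amounts and higher numbers for an effect only at larger amounts of compound), compound 1 holds the only actual number, 20 ug/mL, and this is the anchor here. Compound 2 stands at > 100 ug/mL, which is a limit of the assay. Compound 3 `O=C1/C(=C\c2cccc(Br)c2)c2ccccc2N1c1c(Cl)cccc1Cl` has not yet been measured. It differs from compound 1 by 3-bromophenyl in place of 4-hydroxyphenyl on a double-bonded chain carbon bound to a double-bonded ring carbon, with 3-bromophenyl in place of 4-hydroxyphenyl. For the measured compounds named here, no measured step covers this change. In this assay a modest 1.5-fold higher number from compound 1 to compound 3 (0.18 log units; within the scatter) towards higher numbers is expected. For compound 3 the estimated value is 30 ug/mL, with an expected range from 10 ug/mL to 90 ug/mL.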

Compound 3, concentration for half-maximal effect: 5 ug/mL
The estimate for compound 3 lay 6.0-fold (0.78 log units) above the measured number; measured number below the stated range.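

In this assay, replacing the group on a double-bonded chain carbon bound to a double-bonded ring carbon gives a 4.0-fold lower number from compound 1 to compound 3 (0.60 log units; beyond the scatter). The 4-hydroxyphenyl, with its hydrogen-bond donor and acceptor, is therefore not required for activity at this position: 3-bromophenyl, with neither, gives the lower number. Nothing measured here accounts for the step.

Two things change at once, the substituent and its place on the ring, so the compounds shown leave their contributions unseparated. From the compounds shown here alone, how 3-hydroxyphenyl, 4-bromophenyl or an aminophenyl would read at this position remains open.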